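The compounds below may be only part of what the source reports. "The series", "measured", "known", "first", "only" and "open" are said of these compounds alone.

Measured compounds:
compound 1 `CCN(CC)S(=O)(=O)c1ccc(S(=O)(=O)N2CCC[C@@H](C(=O)N3CCC(F)(F)CC3)C2)cc1` — 16 nM
compound 2 `CCN(CC)S(=O)(=O)c1ccc(S(=O)(=O)N2CCC[C@@H](C(=O)N[C@@H]3CCOC3)C2)cc1` — 750 nM

Among the measured compounds shown here, in a functional assay on MIA PaCa-2 cells (Homo sapiens) for inhibition, read by MTT assay, with a stated time of 7 days (on this read-out higher numbers stand for weaker inhibition and lower numbers for stronger inhibition), compound 2 gives the highest of the two numbers; its only neighbour is compound 1 at 16 nM.

Compound 3 `CCN(CC)S(=O)(=O)c1ccc(S(=O)(=O)N2CCC[C@@H](C(=O)N3CC[C@@H](OC)C3)C2)cc1` differs from compound 2 in one place: 3-methoxypyrrolidin-1-yl in place of (oxolan-3-yl)amino on a carbonyl carbon. For the measured compounds named here, the one measured step that bears on this is a 47-fold higher number from compound 1 to compound 2 (1.67 log units; beyond the scatter), where the amide nitrogen ceased to be part of a ring. Compound 3 puts the amide nitrogen back into a ring, though as 3-methoxypyrrolidin-1-yl rather than the 4,4-difluoropiperidin-1-yl of compound 1, so a partial return toward the lower number is expected. The expected step is a 13-fold lower number from compound 2 to compound 3 (1.10 log units; beyond the scatter). Compound 3 is estimated at 60 nM, within 15 nM to 250 nM.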

Compound 3, half-maximal inhibitory concentration: 3910 nM
For compound 3 the middle estimate is 65-fold (1.81 log units) below the measured one, and the stated range ends below it.
By their numbers in this assay, from the lowest: compound 1; then compound 2; then compound 3.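

In this assay, putting the amide nitrogen back into a ring does not by itself restore the low number: 3-methoxypyrrolidin-1-yl in place of (oxolan-3-yl)amino goes the other way (a 5.2-fold higher number from compound 2 to compound 3 (0.72 log units; beyond the scatter)). Ring-bound amide nitrogens in fact span the whole range, as the change from 4,4-difluoropiperidin-1-yl to 3-methoxypyrrolidin-1-yl shows (a 240-fold higher number from compound 1 to compound 3 (2.39 log units; beyond the scatter)). No measurement at hand gives a cause for this.

Open, as far as these compounds go, is whether the low number of compound 1 goes with its six-membered ring or with its two fluorines. Piperidin-1-yl without fluorine and pyrrolidin-1-yl without methoxy would separate these.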